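Dropping the side chain: from compound 2 to compound 4

The source may report more compounds than this note shows. Statements on the series, on what has been measured and on what is new or still open speak of the compounds shown alone.

Of the compounds shown here, three share a purine-type core and have been tested in a functional assay on the whole organism (Tail, strain ICR) with Mus musculus as the target, in the tail flick test, with a stated time of 90 min, at a dose of 25 umol/kg by the oral route; a higher number here means a stronger effect of the compound at the dose given, a lower number a weaker effect. Compound 1 `N=C(N)NCCC[C@H](NC(=O)CN(c1ncnc2c1ncn2C1CCCCO1)C1CC1)C(=O)OCc1ccccc1` gives 61.6%, compound 2 `CSCC[C@H](NC(=O)CN(c1nc(Cl)nc2[nH]cnc12)C1CC1)C(=O)OCc1ccccc1` gives 44.6%, and compound 3 `C[C@@H](O)[C@H](NC(=O)CN(c1nc(Cl)nc2[nH]cnc12)C1CC1)C(=O)O` gives 35.9%. Compound 2 stands clearly below compound 1, a gap beyond the usual scatter, while compound 2 and compound 3 cannot be told apart within that scatter.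

Compound 4 `O=C(CN(c1nc(Cl)nc2[nH]cnc12)C1CC1)NCC(=O)OCc1ccccc1` is not yet measured. It differs from compound 2 in one place: hydrogen in place of 2-(methylsulfanyl)ethyl on a saturated chain carbon bound to an amide-type nitrogen and a carbonyl carbon.

For the measured compounds named here, no measured pair shows such a step. Compound 3 also carries a smaller side chain than compound 2. In this assay compound 3 gives 35.9%, so the step is expected to be small, at most a mild loss, a number 7.6 percentage points lower from compound 2 to compound 4 (within the scatter). Compound 4 is therefore estimated at 37%, with a likely range from 20% to 56%.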

Compound 4, a percentage reported as activity, at one dose (the size of the read-out at that dose, not a potency): 27.2%
Compound 4: middle estimate off by 9.8 percentage points, on the high side; measured number inside the range.
By their numbers in this assay, from the lowest: compounds 4, 3 and 2 (each within the scatter of the next, the first and the last beyond it); then compound 1.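

In this assay, putting hydrogen in place of 2-(methylsulfanyl)ethyl on this saturated chain carbon gives a number 17.4 percentage points lower from compound 2 to compound 4 (beyond the scatter). For the compounds shown here, this is the first comparison at this position that changes only one place, and it shows that the side chain matters: without it, the effect of compound 2 is not kept. Nothing measured here explains the step.

Still open, going by these compounds, is how a single methyl group, a longer chain or an amine on this carbon would compare with compound 2 and compound 4.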